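A few compounds are considered here, and "the series" means these few. Any claim that something is new, unique, unknown or untested is made for them only; others in the source may bear on it.

The measured compounds and their values:

Compound 1, `C/C=C/C(=O)N(Cc1ccc(OC)c(OC)c1)c1cc(OC)c(OC)c(OC)c1`, 20100 nM
Compound 2, `C/C=C/C(=O)N(Cc1ccc(OC)c(C)c1)c1cc(OC)c(OC)c(OC)c1`, 14500 nM
Compound 3, `COc1ccc(CNc2cc(OC)c(OC)c(OC)c2)cc1`, 11400 nM

All three were tested in a functional assay on MGC-803 cells (Homo sapiens) for inhibition, read by MTT assay, with a stated time of 48 h; on this read-out higher numbers stand for weaker inhibition and lower numbers for stronger inhibition. Compound 1 and compound 2 differ in one place: methyl in place of methoxy on an aromatic carbon. That change gave a 1.4-fold lower number from compound 1 to compound 2 (0.14 log units; within the scatter). Compound 3 carries a different core, and how it differs from compound 1 is not broken down here; its value sits within the scatter of both compound 1 and compound 2, so no order among the three can be read from these numbers.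

Compound 4, `COc1cc(NCc2ccc(C)cc2)cc(OC)c1OC`, is not yet measured. It arises from compound 3 by the same kind of change as compound 2 from compound 1: methyl in place of methoxy on an aromatic carbon. The place is not the same, since in compound 1 the methoxy sat ortho to a methoxy group and meta to a large group, while in compound 3 it sits para to a large group.

Because the change from compound 1 to compound 2 gave a 1.4-fold lower number from compound 1 to compound 2 (0.14 log units; within the scatter), the step from compound 3 to compound 4 is expected to be a 1.2-fold lower number from compound 3 to compound 4 (0.08 log units; within the scatter). Compound 4 is therefore estimated at 9500 nM, between 4000 nM and 25000 nM.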

Compound 4, half-maximal inhibitory concentration: > 80000 nM
Compound 4 was reported as a limit (the forecaster's own chance of this, stated with the estimate: 5%); middle value at least 8.4-fold (0.92 log units) away from the limit.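

In this assay, methyl in place of methoxy on an aromatic carbon, para to a large group, gave an at least 7.0-fold higher number from compound 3 to compound 4 (0.84 log units; beyond the scatter). For compound 4 the value of > 80000 nM is a limit of the assay and not a number. The change therefore did not carry over as one shift from the core of compound 1 to the core of compound 3, although with only two pairs, and with the methoxy leaving a different place in each, these data do not show whether the core or the place accounts for the gap, nor do they give a cause: the same change on two cores in this assay, a 1.4-fold lower number (0.14 log units; within the scatter) from compound 1 to compound 2 and an at least 7.0-fold higher number (0.84 log units; beyond the scatter) from compound 3 to compound 4, at least 9.7-fold (0.98 log units) apart, beyond the scatter of two such steps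

The compounds shown leave open whether the outcome on the core of compound 3 is specific to methyl or would also appear with another group on the same aromatic carbon, such as a hydroxyl, a chlorine or an ethyl. They also leave open how either core would respond to a change elsewhere, such as a carboxylic acid or a longer chain on the nitrogen.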